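Pyridyl in Place of Tolyl on the Amide Carbonyl

The compounds below may be only part of what the source reports. "The series", "measured", "known", "first", "only" and "open" are said of these compounds alone.

Three amides on one shared core were examined in a toxicity assay on THP-1 cells (Homo sapiens) for inhibition; on this read-out lower numbers stand for higher toxicity in this test and higher numbers for lower toxicity in this test. Compound 1 `COc1ccc(-c2cnc(NC(=O)c3cccc(OC)c3)n2C)cc1` carries a 3-methoxyphenyl group on the carbonyl carbon. In this assay compound 1 reaches only the limit of the test, > 100000 nM. Compound 2 `COc1ccc(-c2cnc(NC(=O)c3ccc(Cl)cc3)n2C)cc1` carries 4-chlorophenyl in that place. In this assay compound 2 likewise stops at a limit, > 100000 nM. Compound 3 `COc1ccc(-c2cnc(NC(=O)c3ccc(C)cc3)n2C)cc1` carries 4-methylphenyl. In this assay compound 3 also gives only a limit, > 100000 nM. Compound 3 thus stands where the other two stand: all three values are limits, as the limit of > 100000 nM in this assay, at which 3 of the 3 values shown sit, records. The steps between them, a step that the two limits leave unreadable from compound 1 to compound 2, a step that the two limits leave unreadable from compound 1 to compound 3 and a step that the two limits leave unreadable from compound 2 to compound 3, cannot be sized, each end being a limit.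

Compound 4 `COc1ccc(-c2cnc(NC(=O)c3ccncc3)n2C)cc1` remains to be measured. It differs from compound 3 in one place: pyridin-4-yl in place of 4-methylphenyl on a carbonyl carbon. The three measured steps bear on this change only in showing that exchanging the aryl group on the carbonyl carbon has not moved any compound off the limit. The expected step from compound 3 to compound 4 in this assay is therefore a number no higher from compound 3 to compound 4 (the limit leaves the size open), none beyond the scatter. Compound 4 is expected to give 100000 nM, in a range from 40000 nM to 300000 nM.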

Compound 4, half-maximal cytotoxic concentration: > 100000 nM
Compound 4 gave a limit, no number; the forecaster's own chance of this, stated with the estimate: 85%; the middle value lies on the limit itself.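

Compound 4 stops at a limit, as compound 1, compound 2 and compound 3 do, so none of its steps to those three compounds in this assay can be read: the limit of > 100000 nM in this assay, at which 4 of the 4 values shown sit.

The compounds shown leave open whether any group on the carbonyl carbon would bring a value off that limit.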